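The source may report more compounds than this note shows. Statements on the series, on what has been measured and on what is new or still open speak of the compounds shown alone.

The compounds described here share one core and differ only in the group carried on a nitrogen on an aromatic ring. Their activity is read in a functional assay on blood (Homo sapiens) for inhibition; on this read-out higher numbers stand for weaker inhibition and lower numbers for stronger inhibition. Among the measured compounds shown here, compound 1 `CCC(C)CNc1cc(-c2[nH]c(SC)nc2-c2ccc(F)cc2)ccn1` is the only member with a number: in this assay compound 1 gives 2760 nM. Compound 2 `CSc1nc(-c2ccc(F)cc2)c(-c2ccnc(NCc3cccnc3)c2)[nH]1` was run in this assay, but for compound 2 the entry reads "not determined" (no result reported), with no result reported. Compound 3 `CSc1nc(-c2ccc(F)cc2)c(-c2ccnc(N[C@H]3CC[C@@H](C)CC3)c2)[nH]1` likewise has no number in this assay, where compound 3 reads "not determined" (no result reported), so it cannot be placed on the numbers; compound 2 stands in the same situation, leaving compound 1 as the single anchor. Compound 4 `CCC(Nc1cc(-c2[nH]c(SC)nc2-c2ccc(F)cc2)ccn1)c1ccccc1` has not yet been measured. The change from compound 3 to compound 4 is 1-phenylpropyl in place of 4-methylcyclohexyl on a nitrogen on an aromatic ring. For the measured compounds named here, with no number for compound 3 and no step between any two measured compounds, there is no basis on which to size the step in this assay or to give its direction; whether it falls within or beyond the scatter is unknown. Going by the values given here, the only guide is compound 1, which carries a different group at the same place and gives 2760 nM. On that footing the expected value for compound 4 in this assay is 2000 nM. Among the compounds with values here, that estimate is expected to lie between 400 nM and 10000 nM, a wide range because the sole support is compound 1 at 2760 nM.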

Compound 4, half-maximal inhibitory concentration: 7640 nM
Estimate against measurement, compound 4: 3.8-fold (0.58 log units) below, within the range that was stated.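

In this assay, the group on the nitrogen on the aromatic ring now has a measurable effect: 1-phenylpropyl in place of 2-methylbutyl gives a 2.8-fold higher number from compound 1 to compound 4 (0.44 log units; beyond the scatter). Since a higher number stands for weaker inhibition, this one pair shows that the position is not indifferent to its group, and that this particular change lowers inhibition by more than repeat measurements would be expected to vary. Nothing available explains this difference, and a single pair sets no trend for the position.

The step from compound 3 to compound 4 cannot be read, nor can any step involving compound 2, as neither compound 2 nor compound 3 has a number, so the groups they carry stay unplaced relative to compound 1 and compound 4. As far as these compounds go, it also remains open whether the drop follows from the aromatic ring or from the branched chain that holds it, a question that a plain benzyl group, a straight butyl chain or a longer chain ending in an amine at the same nitrogen could begin to answer.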